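The source may report more compounds than this note shows. Statements on the series, on what has been measured and on what is new or still open speak of the compounds shown alone.

Measured in an ADME assay (liver) for metabolic stability, with Liver microsome (Homo sapiens) as the target, using microsomes; on this read-out lower numbers stand for slow clearance and higher numbers for fast clearance:

Compound 1 `Cc1cnc(NC(=O)c2cc(Oc3cnc(C(=O)N(C)C)cn3)c3cc(C)oc3c2)cn1`: < 8.5 mL/min/kg, which is a limit of the assay and not a number.
Compound 2 `Cc1cnc(NC(=O)c2cc(Oc3ccc(C(=O)N(C)C)nc3)c3cc(C)oc3c2)cn1`: 11.6 mL/min/kg.
Compound 3 `Cc1ccc(Oc2cc(C(=O)Nc3cnc(C)cn3)cc3oc(C)cc23)cc1`: 47 mL/min/kg.

Compound 3 gives the highest of the two actual numbers in this assay, at 47 mL/min/kg. The nearest compound is compound 2, with 11.6 mL/min/kg, and the gap between the two lies beyond the scatter. Compound 1 offers only its limit for comparison.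

The next compound to be tested is compound 4 `Cc1cnc(NC(=O)c2cc(Oc3ccc(S(C)(=O)=O)cc3)c3cc(C)oc3c2)cn1`. It has methylsulfonyl in place of the methyl of compound 3, on an aromatic carbon of a six-membered aromatic ring of carbon only, para to a large group (methylsulfonyl in place of methyl on an aromatic carbon). No single-place change has been measured in this small set, so the direct evidence for this step is missing. Among the measured compounds shown here, the only numeric guide is compound 2, which also lacks that methyl and gives 11.6 mL/min/kg, though it differs from compound 3 in more than this one place. A fall in clearance beyond the scatter is therefore expected, and the estimated step is a 3.6-fold lower number from compound 3 to compound 4 (0.56 log units; beyond the scatter). For compound 4 the estimated clearance is 13 mL/min/kg, with an expected range from 8 mL/min/kg to 26 mL/min/kg.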

Compound 4, clearance in the Liver microsome assay: 13 mL/min/kg
The estimate for compound 4 equals the measured number at the digits printed; the range from low to high includes it.
By their numbers in the Liver microsome assay, from the lowest: compounds 2 and 4 (each within the scatter of the next); then compound 3. At a limit, below all of these: compound 1.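

Among the compounds shown here, in the Liver microsome assay, replacing methyl with methylsulfonyl at this position gives the first step in the set that can be read in one place, and clearance falls beyond the scatter (a 3.6-fold lower number from compound 3 to compound 4 (0.56 log units; beyond the scatter)). For the compounds shown here, compound 3 and compound 4 share everything else, so this shift traces to the single exchange on the six-membered aromatic ring of carbon only, para to a large group, something none of the earlier compounds could show. The same exchange also comes at a price in a physicochemical assay for solubility, measured as kinetic solubility (on this read-out higher numbers stand for higher solubility and lower numbers for lower solubility), where the number drops beyond the scatter too: the measured solubility of compound 3, 18000 nM, and of compound 4, 3000 nM, a 6.0-fold lower number (0.78 log units; beyond the scatter). In the physicochemical assay compound 3 gives 18000 nM and compound 4 gives 3000 nM.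

The compounds shown leave open whether the lower clearance needs the methylsulfonyl group at all, or would also follow from another group at this position, such as a nitrile, a primary amide or a carboxylic acid, and whether solubility would then stay closer to that of compound 3. A single step also leaves open whether the exchange would read the same way with a different amide on the shared core.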